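The source may report more compounds than this note shows. Statements on the series, on what has been measured and on what is new or still open speak of the compounds shown alone.

Measured compounds:
- compound 1 `COc1ccc(C(=O)/C=C/c2ccc(F)cc2)c2c1C=CC(C)(C)O2`: > 10000 nM
- compound 2 `COc1ccc(C(=O)/C=C/c2ccc(Br)cc2)c2c1C=CC(C)(C)O2`: > 10000 nM
- compound 3 `COc1ccc(C(=O)/C=C/c2cccc3ccccc23)c2c1C=CC(C)(C)O2`: > 10000 nM

Compound 1 was tested in a functional assay on K562 cells (Homo sapiens) for antiproliferative activity, read by MTT assay, with a stated time of 24 h; a lower number here means a stronger inhibitor, a higher number a weaker inhibitor. In this assay compound 1 gives > 10000 nM, which is a limit of the assay and not a number. Compound 2 also gives only a limit, > 10000 nM. Compound 3 likewise gives only a limit, > 10000 nM. All three values therefore sit at the same place: the limit of > 10000 nM in this assay, at which 3 of the 3 values shown sit. Among the compounds with values here, the one step between measured compounds that differ in a single place, a step that the two limits leave unreadable from compound 1 to compound 2, cannot be read in size, since both ends are limits.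

Compound 4 `COc1ccc(C(=O)/C=C/c2cccc(O)c2)c2c1C=CC(C)(C)O2` is the unmeasured compound. It differs from compound 1 as follows: 3-hydroxyphenyl in place of 4-fluorophenyl on a double-bonded chain carbon bound to a double-bonded chain carbon. Within the data shown here, no measured step involves a hydroxyl group entering, so the only comparison at hand is the unreadable fluoro-to-bromo step, and the shared core with three different aryl groups has so far given nothing but limits. The step from compound 1 to compound 4 is accordingly expected to be a step that the limit leaves unreadable from compound 1 to compound 4, meaning no readable change. Compound 4 is estimated at 15000 nM, with a range from 3000 nM to 80000 nM.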

Compound 4, half-maximal inhibitory concentration: > 10000 nM
Compound 4: no number, only a limit; the forecaster's own chance of this, stated with the estimate: 75%; the middle value does not contradict the limit.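

Compound 4, like compound 1 and compound 2, gives only a limit and not a number, so the steps from compound 1 and compound 2 to compound 4 cannot be read in size. The compounds shown leave open whether any of these aryl groups changes activity on the shared core, and by how much, as every result is a limit: the limit of > 10000 nM in this assay, at which 4 of the 4 values shown sit.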